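This account rests on a few compounds, and the source may have more. Where it says the series, first, only, none or still open, it means among the compounds named here.

In a physicochemical assay for solubility (a lower number here means a less soluble compound, a higher number a more soluble compound), compound 1 (`O=C(c1ccccc1)N1CCC(NS(=O)(=O)c2cc(S(=O)(=O)c3ccccc3)ccc2C(F)(F)F)CC1`) gives 12500 nM, compound 2 (`O=C(O)c1cccc(S(=O)(=O)N2CCC(NS(=O)(=O)c3cc(S(=O)(=O)c4ccccc4)ccc3C(F)(F)F)CC2)c1`) gives 12500 nM, and compound 3 (`O=C(O)c1ccc(S(=O)(=O)N2CCC(NS(=O)(=O)c3cc(S(=O)(=O)c4ccccc4)ccc3C(F)(F)F)CC2)cc1`) gives 12500 nM. Compound 3 therefore stands level with the other two. The next structure, compound 4 (`O=C(O)CCCC(=O)N1CCC(NS(=O)(=O)c2cc(S(=O)(=O)c3ccccc3)ccc2C(F)(F)F)CC1`), keeps the shared core and alters only the group on an amine nitrogen in a ring: (3-carboxypropyl)carbonyl in place of (4-carboxyphenyl)sulfonyl on an amine nitrogen in a ring.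

Among the measured compounds shown here, three measured steps bear on this change. Placing (3-carboxyphenyl)sulfonyl on that nitrogen in place of benzoyl gave no change at the digits printed from compound 1 to compound 2 (within the scatter). Placing (4-carboxyphenyl)sulfonyl there gave no change at the digits printed from compound 1 to compound 3 (within the scatter). Exchanging 3-carboxyphenyl for 4-carboxyphenyl on the sulfonyl sulfur gave no change at the digits printed from compound 2 to compound 3 (within the scatter). For the measured compounds named here, each of these replacements left this assay within the scatter, and they are the only evidence at this position. Going by the values given here, no measured compound carries a group without a ring at that nitrogen, so the new chain remains untested and the range has to stay fairly wide.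

On this evidence, no step beyond the scatter is expected in either direction. The expected step is no change at the digits printed from compound 3 to compound 4 (within the scatter). For compound 4 the estimated value is 12500 nM, with an expected range from 7000 nM to 20000 nM.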

Compound 4, solubility: 50000 nM
For compound 4 the middle estimate is 4.0-fold (0.60 log units) below the measured one; the measured number lies above the stated range.
By their numbers in this assay, from the lowest: compounds 1, 2 and 3 (each within the scatter of the next); then compound 4.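

At the amine nitrogen in a ring, the earlier replacements had all stayed within the scatter in this assay, whereas the (3-carboxypropyl)carbonyl group moves the read-out beyond it, giving a 4.0-fold higher number from compound 3 to compound 4 (0.60 log units; beyond the scatter) and likewise a 4.0-fold higher number from compound 2 to compound 4 (0.60 log units; beyond the scatter) when (3-carboxyphenyl)sulfonyl is the group replaced. The carbonyl need not change for this step to appear, since 3-carboxypropyl in place of phenyl on the carbonyl carbon gives a 4.0-fold higher number from compound 1 to compound 4 (0.60 log units; beyond the scatter) as well, and among these compounds only compound 4 has no ring in the group on that nitrogen. Nothing given here accounts for the step.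

The compounds shown do not separate the loss of the ring from the length of the chain, so a shorter or longer chain ending in a carboxylic acid could still go either way. Nor do they show what the carboxylic acid contributes on this chain, which a plain butanoyl group, a methyl ester or a chain ending in an amine at the same nitrogen would address.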